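A few compounds are considered here, and "the series" means these few. Any claim that something is new, unique, unknown or untested is made for them only; others in the source may bear on it.

Among the measured compounds shown here, in an ADME assay on microsomes from liver (Homo sapiens) for metabolic stability, read by LC-MS, using NADPH, tested at 5 uM (on this read-out lower numbers stand for a shorter-lived compound and higher numbers for a longer-lived compound), the three measured members are compound 1 `Cc1cc(S(=O)(=O)/N=C(\N)n2nccc2-c2ccccc2)c(SCc2ccc(Cl)cc2)cc1Cl`, compound 2 `Cc1cc(S(=O)(=O)/N=C(\N)n2nccc2-c2ccccc2)c(SCc2cccc3ccccc23)cc1Cl` and compound 3 `Cc1ccc(CSc2cc(Cl)c(C)cc2S(=O)(=O)/N=C(\N)n2nccc2-c2ccccc2)cc1`. Compound 1 gives 0.34 h, compound 2 gives 0.268 h and compound 3 gives 0.13 h. Compound 3 stands lowest of the three numbers: its nearest neighbour is compound 2, with a 2.1-fold lower number from compound 2 to compound 3 (0.31 log units; beyond the scatter), and the gap to compound 1 is wider, with a 2.6-fold lower number from compound 1 to compound 3 (0.42 log units; beyond the scatter). The next compound in the set is compound 4 `Cc1cc(S(=O)(=O)/N=C(\N)n2nccc2-c2ccccc2)c(SCc2ccccc2C(F)(F)F)cc1Cl`, not yet measured. Relative to compound 3 the change is 2-(trifluoromethyl)phenyl in place of 4-methylphenyl on a saturated chain carbon bound to a sulfur. Two measured steps already alter the group on the saturated chain carbon bound to a sulfur: a 1.3-fold lower number from compound 1 to compound 2 (0.10 log units; within the scatter) and a 2.1-fold lower number from compound 2 to compound 3 (0.31 log units; beyond the scatter). Swaps at this position have thus produced shifts ranging from none beyond the scatter to a modest one. For the measured compounds named here, the two compounds carrying a group other than 4-methylphenyl there, compound 1 and compound 2, both sit above compound 3, so an upward move is the more likely direction for this exchange, but a step larger than modest has no precedent at this site. The expected step is therefore a 1.9-fold higher number from compound 3 to compound 4 (0.28 log units; within the scatter), a modest rise that would still leave the result below compound 1. Compound 4 is estimated at 0.25 h, with a range of 0.12 h to 0.5 h.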

Compound 4, half-life: 0.15 h
Compound 4: the middle estimate sits 1.7-fold (0.22 log units) above what was measured; measured number inside the range.
By their numbers in this assay, from the lowest: compounds 3, 4, 2 and 1 (each within the scatter of the next, the first and the last beyond it).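

In this assay the exchange on a saturated chain carbon bound to a sulfur shows a 1.2-fold higher number from compound 3 to compound 4 (0.06 log units; within the scatter) and, against the bicyclic group, a 1.8-fold lower number from compound 2 to compound 4 (0.25 log units; within the scatter) as well, so 2-(trifluoromethyl)phenyl cannot be told apart from either 4-methylphenyl or naphthalen-1-yl, even though those two groups are separated from each other by a step beyond the scatter. Only the comparison with 4-chlorophenyl clears the scatter, as a 2.3-fold lower number from compound 1 to compound 4 (0.36 log units; beyond the scatter) shows, and with four groups now read at this position, the largest step between any two of them remains modest, while compound 1 keeps the highest printed half-life, though within the scatter of compound 2. No supporting measurement bears on these steps, and no reason for them can be given.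

As far as these compounds go, all four groups at this position carry a six-membered aromatic ring of carbon only or the naphthalen-1-yl system, so the effect of a pyridine ring, an amine or a carboxylic acid on the half-life remains open. From the compounds shown here alone, it also remains open whether 4-(trifluoromethyl)phenyl would read with 2-(trifluoromethyl)phenyl or with 4-chlorophenyl at this position.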